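This account rests on a few compounds, and the source may have more. Where it says the series, first, only, none or still open, it means among the compounds named here.

Within the data shown here, compound 2 `COc1ccc(-c2csc(N3N=C(c4ccc(C)s4)CC3c3ccc(F)cc3)n2)cc1` carries a methoxy group and is the only compound here with a measured number: in a functional assay on A549 cells (Homo sapiens) for antiproliferative activity, read by XTT assay, with a stated time of 24 h (a higher number here means a weaker inhibitor, a lower number a stronger inhibitor), compound 2 gives 184 ug/mL. Compound 1 `N#Cc1ccc(-c2csc(N3N=C(c4ccc(Cl)s4)CC3c3ccc(F)cc3)n2)cc1` is known only as a limit of the assay, > 500 ug/mL, so it offers no number to compare against. Compound 3 `Cc1ccc(C2=NN(c3nc(-c4ccc(C#N)cc4)cs3)C(c3ccc(F)cc3)C2)s1` has not yet been measured. It differs from compound 2 in one place (cyano in place of methoxy on an aromatic carbon), that is, cyano in place of methoxy on an aromatic carbon. Among the measured compounds shown here, no step between two measured compounds is available to show how large such a change runs. Compound 1, which also carries a cyano group, sits at the limit of > 500 ug/mL in this assay, at which 1 of the 2 values shown sits. On that basis a step toward weaker inhibition, beyond the usual scatter, is expected in this assay, a 1.9-fold higher number from compound 2 to compound 3 (0.28 log units; within the scatter). For compound 3 the expected value in this assay is 350 ug/mL, with a likely range from 150 ug/mL to 800 ug/mL, and a real chance that only a limit is reported.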

Compound 3, half-maximal inhibitory concentration: 322 ug/mL
Compound 3: middle estimate off by 1.1-fold (0.04 log units), on the high side; measured number inside the range.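

With a measured number on each side, the place para to a large group now has its first real step: in this assay, cyano in place of methoxy gives a 1.8-fold higher number from compound 2 to compound 3 (0.24 log units; within the scatter), so compounds 2 and 3 cannot be told apart. Compound 1 gives > 500 ug/mL, which is a limit and not a number. Compound 3 carries the same cyano group yet returns a number, so cyano alone does not place a compound at that limit, while methyl in place of chloro on an aromatic carbon gives an at least 1.5-fold lower number from compound 1 to compound 3 (0.19 log units; that floor lies within the scatter), too small a floor to establish a real difference.

On these data alone, it remains open whether an amine, a carboxylic acid or a longer chain such as butoxy at this place would move the number beyond the scatter. As far as these compounds go, how methoxy would behave alongside chloro also remains open.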